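Halogen position swap in a thiourea series at the vanilloid receptor

A few compounds are considered here, and "the series" means these few. Any claim that something is new, unique, unknown or untested is made for them only; others in the source may bear on it.

Measured so far:
compound 1 `COc1cc(CNC(=S)NCC(COC(=O)C(C)(C)C)Cc2ccc(C)c(C)c2)cc(I)c1O` — 232 nM
compound 2 `COc1cc(CNC(=S)NCC(COC(=O)C(C)(C)C)Cc2ccc(C)c(C)c2)c(Br)cc1O` — 19.9 nM
compound 3 `COc1cc(CNC(=S)NC(CCc2ccc(C(C)(C)C)cc2)COC(=O)C(C)(C)C)cc(I)c1O` — 214 nM

Compound 1 and compound 2 share one core; between them the change is 2-bromo-4-hydroxy-5-methoxyphenyl in place of 4-hydroxy-3-iodo-5-methoxyphenyl on a saturated chain carbon bound to an amide-type nitrogen. In an assay on CHO cells for displacement of a labelled ligand from transient receptor potential cation channel subfamily V member 1 (Rattus norvegicus) (on this read-out lower numbers stand for stronger inhibition and higher numbers for weaker inhibition), this gave a 12-fold lower number from compound 1 to compound 2 (1.07 log units; beyond the scatter), a step beyond the scatter. Compound 3 carries a different core; how the core of compound 3 differs from that of compound 1 is not broken down here, and compound 3 and compound 1 give numbers within the scatter of each other in this assay.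

Compound 4 `COc1cc(CNC(=S)NC(CCc2ccc(C(C)(C)C)cc2)COC(=O)C(C)(C)C)c(Br)cc1O` is not yet measured. Relative to compound 3 the change is 2-bromo-4-hydroxy-5-methoxyphenyl in place of 4-hydroxy-3-iodo-5-methoxyphenyl on a saturated chain carbon bound to an amide-type nitrogen, the same change as from compound 1 to compound 2, at the same place. The expectation for compound 4 rests on that one earlier step; whether it carries over to the second core is not shown by any measured pair. On that basis compound 4 is expected to give 22 nM in this assay, with a range from 8 nM to 65 nM. This estimate implies a step of a 9.7-fold lower number from compound 3 to compound 4 (0.99 log units; beyond the scatter), expected to mirror the earlier one.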

Compound 4, inhibition constant: 75 nM
Compound 4: the middle estimate sits 3.4-fold (0.53 log units) below what was measured, and the stated range ends below it.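

In this assay, the swap of 4-hydroxy-3-iodo-5-methoxyphenyl for 2-bromo-4-hydroxy-5-methoxyphenyl on the second core gives a 2.9-fold lower number from compound 3 to compound 4 (0.46 log units; beyond the scatter) and so keeps the direction seen on the first core. The size of the step does not carry over between the two cores: the same change on two cores in this assay, a 12-fold lower number (1.07 log units; beyond the scatter) from compound 1 to compound 2 and a 2.9-fold lower number (0.46 log units; beyond the scatter) from compound 3 to compound 4, 4.1-fold (0.61 log units) apart, beyond the scatter of two such steps

Direction therefore held on both cores, but these two pairs give no basis for assuming a fixed size on a further core. They do not show which part of the core difference goes with the smaller step, and they do not separate the exchange of iodine for bromine from the shift in where the halogen sits on the ring.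

Still open, as far as these compounds go, is whether chlorine in place of the bromine gives a step of the same direction and size. Also open, from the compounds shown here alone, is whether the swap behaves alike with a urea in place of the thiourea or a free hydroxyl in place of the pivalate ester.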